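This account rests on a few compounds, and the source may have more. Where it says the series, first, only, none or still open, it means among the compounds named here.

Among the measured compounds shown here, in an assay on L cells for inhibition of Protein-serine O-palmitoleoyltransferase porcupine (Mus musculus), read by reporter gene assay, with a stated time of 24 h (a lower number here means that less compound is needed, a higher number that more compound is needed for the effect), compound 2 `COc1ccc(-n2c(SCC(=O)Nc3nc4ccc(C(F)(F)F)cc4s3)nc3c(c2=O)SCC3)cc1` gives 100 nM, the higher of the two numbers measured so far. For the measured compounds named here, its only neighbour, compound 1 `COc1ccc(-n2c(SCC(=O)Nc3nc4ccc(Cl)cc4s3)nc3c(c2=O)SCC3)cc1`, gives 35 nM in this assay, and the single measured step, a 2.9-fold higher number from compound 1 to compound 2 (0.46 log units; beyond the scatter), separates them. Compound 3 `COc1ccc(-n2c(SCC(=O)Nc3nc4ccc(OC)cc4s3)nc3c(c2=O)SCC3)cc1` differs from compound 2 in one place: methoxy in place of trifluoromethyl on an aromatic carbon. Going by the values given here, no measured step shows what a methoxy does at this aromatic carbon. The step from compound 1 to compound 2 bears on it only indirectly, by showing that exchanging the group at this place moved the number by a modest amount. With the direction open, the expected step of a 1.4-fold lower number from compound 2 to compound 3 (0.15 log units; within the scatter) is taken as small, within or near the scatter. The estimate for compound 3 in this assay is therefore 70 nM, with a wide range from 25 nM to 200 nM reflecting the absence of a direct precedent.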

Compound 3, half-maximal effective concentration: 120 nM
Beside the measured number, compound 3's estimate is 1.7-fold (0.23 log units) below it, and the stated range covers the measured number.
By their numbers in this assay, from the lowest: compound 1; then compounds 2 and 3 (each within the scatter of the next).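

In this assay, methoxy and trifluoromethyl cannot be told apart at this aromatic carbon: the measured result is a 1.2-fold higher number from compound 2 to compound 3 (0.08 log units; within the scatter) and gives no direction, even though methoxy has fewer heavy atoms and carries a hydrogen-bond acceptor that trifluoromethyl lacks. Chloro now stands apart from two different groups rather than one, with a 3.4-fold higher number from compound 1 to compound 3 (0.54 log units; beyond the scatter) adding to the earlier step to trifluoromethyl, so compound 1 alone holds the lower number among these three compounds. Nothing available here explains why chloro differs from the other two groups.

On these data alone, whether fluoro, bromo, a bare hydrogen, an amine or a carboxylic acid at this aromatic carbon would match chloro or the other two groups stays open. As far as these compounds go, all three compounds also share one core, so whether chloro would keep its lower number on a different core is unknown.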